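Capping a hydroxy on the shared core

The compounds below may be only part of what the source reports. "The series", "measured", "known", "first", "only" and "open" are said of these compounds alone.

Measured in a functional assay on L1210 cells (Mus musculus) for antiproliferative activity, with a stated time of 4 h; a higher number here means a weaker inhibitor, a lower number a stronger inhibitor:
compound 1 `O=C1NC(=O)c2c1c1c(O)cccc1c1[nH]c3ccccc3c21`: 19200 nM
compound 2 `O=C1NC(=O)c2c1c1c(O)ccc(O)c1c1[nH]c3ccccc3c21`: 1100 nM
compound 3 `Cc1ccc2[nH]c3c4c(O)ccc(O)c4c4c(c3c2c1)C(=O)NC4=O`: 600 nM

Compound 2 stands at 1100 nM, far under compound 1 and not separable from compound 3. The next compound, compound 4 `CC(C)(C)C(=O)Oc1ccc(O)c2c3c(c4c5ccccc5[nH]c4c12)C(=O)NC3=O`, has (tert-butyl)carbonyl in place of hydrogen on an oxygen on an aromatic ring, a change of hydroxy to ((tert-butyl)carbonyl)oxy: (tert-butyl)carbonyl in place of hydrogen on an oxygen on an aromatic ring. The oxygen so capped belongs to the hydroxy that distinguishes compound 2 from compound 1, so the step that bears most directly is a 17-fold lower number from compound 1 to compound 2 (1.24 log units; beyond the scatter). The methyl step, a 1.8-fold lower number from compound 2 to compound 3 (0.26 log units; within the scatter), lies elsewhere on the core and says little here. Going by the values given here, no measured compound carries an ester, so the step from compound 1 can serve only as a rough guide. A partial move back towards compound 1 is therefore expected, and the estimated change is a 3.6-fold higher number from compound 2 to compound 4 (0.56 log units; beyond the scatter). In this assay, compound 4 is expected at about 4000 nM, within an estimated range of 900 nM to 20000 nM.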

Compound 4, half-maximal inhibitory concentration: 1950 nM
Estimate against measurement, compound 4: 2.1-fold (0.31 log units) above; low and high end bracket the measured number.
By their numbers in this assay, from the lowest: compounds 3, 2 and 4 (each within the scatter of the next, the first and the last beyond it); then compound 1.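

In this assay, capping this oxygen with (tert-butyl)carbonyl gives a 1.8-fold higher number from compound 2 to compound 4 (0.25 log units; within the scatter), so the free hydroxy is not shown to be needed at this position for a number in this range. Set against the core that has only hydrogen on this aromatic carbon, ((tert-butyl)carbonyl)oxy still gives a 9.8-fold lower number from compound 1 to compound 4 (0.99 log units; beyond the scatter), which means that the large drop seen on adding the hydroxy is not lost with the cap. Nothing available here accounts for this tolerance of the cap.

The compounds shown leave open whether a smaller cap such as acetyl or methyl on this oxygen, or an amine in place of the hydroxy, would be tolerated in the same way. They also leave open whether the same ester on the other hydroxy would give a similar result.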